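Cytotoxicity Across a Small Aryl Exchange

The source may hold more compounds than are shown below. What is called first, only, known or untested is meant among the compounds shown, and "the series" means these compounds.

Going by the values given here, compound 1 `CCc1ccc(-c2nc3c(c(C)nn3-c3ccccc3)c(-c3ccccc3Cl)c2C#N)cc1` and compound 2 `CCCc1ccc(-c2nc3c(c(C)nn3-c3ccccc3)c(-c3ccccc3O)c2C#N)cc1` share one core and differ from each other in more than one place, so no single step between them is counted. In an ADME assay on BJ cells (Homo sapiens) for cytotoxicity, with a stated time of 72 h (on this read-out lower numbers stand for an effect already at smaller amounts and higher numbers for an effect only at larger amounts of compound), compound 1 gives only a limit of the assay, > 20000 nM, as recorded by the limit of > 20000 nM in this assay, at which 1 of the 2 values shown sits. In this assay, among the compounds with values here, compound 2 gives 22500 nM, the only plain number in the set.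

Compound 3 `CCc1cccc(-c2nc3c(c(C)nn3-c3ccccc3)c(-c3ccccc3O)c2C#N)c1` is not yet measured. It differs from compound 2 by 3-ethylphenyl in place of 4-propylphenyl on an aromatic carbon. Within the data shown here, no measured pair differing in a single place is available, so the size of this exchange in this assay is not anchored by anything measured. The step of a 1.0-fold lower number from compound 2 to compound 3 (0.01 log units; within the scatter) is expected to stay within the usual scatter, with no direction favored. Compound 3 is therefore expected to give about 22000 nM in this assay, within a range from 10000 nM to 50000 nM. Compound 2 stands at 22500 nM, and compound 3 is expected to fall near it. Compound 1, by contrast, sits at the boundary recorded by the limit of > 20000 nM in this assay, at which 1 of the 2 values shown sits, so a reported limit instead of a number also remains a fair possibility for compound 3.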

Compound 3, half-maximal effective concentration: > 20000 nM
Compound 3: only a limit was reported; the forecaster's own chance of this, stated with the estimate: 40%; the middle value lies beyond the limit too.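

In this assay compound 3 gives > 20000 nM, which is a limit of the assay and not a number. Going by these compounds alone, no step between compound 2 and compound 3 can therefore be read. The compounds shown leave open how large the exchange of 4-propylphenyl for 3-ethylphenyl is, and in which direction it goes, with most of the results resting on a limit: the limit of > 20000 nM in this assay, at which 2 of the 3 values shown sit.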